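Isobutyl for isopropyl on a weakly cytotoxic proline amide

The source may report more compounds than this note shows. Statements on the series, on what has been measured and on what is new or still open speak of the compounds shown alone.

Measured compounds:
- compound 1, `CC(C)[C@H](NC(=O)[C@]1(Cc2ccccc2)CCN1C(=O)OCc1ccccc1)C(N)=O`: 100000 nM
- compound 2, `NC(=O)[C@H](CCC(=O)O)NC(=O)C1(Cc2ccccc2)CCN1C(=O)OCc1ccccc1`: a limit only, > 100000 nM
- compound 3, `CC(C)[C@H](NC(=O)[C@@]1(Cc2ccccc2)CCN1C(=O)OCc1ccccc1)C(N)=O`: 85000 nM

All three share one core and are tested in an ADME assay on HELF cells (Homo sapiens) for cytotoxicity, with a stated time of 3 days; on this read-out lower numbers stand for higher toxicity in this test and higher numbers for lower toxicity in this test. In this assay compound 3 gives 85000 nM and compound 1 gives 100000 nM, two numbers that lie within the scatter of each other. Compound 2 gives only a limit in this assay, > 100000 nM, which means no number was reached. For the measured compounds named here, the only measured step, a 1.2-fold lower number from compound 1 to compound 3 (0.07 log units; within the scatter), concerns a stereocentre and is small, as fits (the fact that compounds 1 and 3 differ only in the configuration as drawn).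

Compound 4, `CC(C)C[C@H](NC(=O)[C@@]1(Cc2ccccc2)CCN1C(=O)OCc1ccccc1)C(N)=O`, differs from compound 3 by a small change on the side chain: isobutyl in place of isopropyl on a saturated chain carbon bound to an amide-type nitrogen and a carbonyl carbon. Going by the values given here, no measured step touches this side chain, so the data give no guide to its effect. Compound 4 is therefore expected to stay close to compound 3, an expected step of a 1.1-fold higher number from compound 3 to compound 4 (0.02 log units; within the scatter). The estimate for compound 4 in this assay is 90000 nM, expected to lie between 45000 nM and 180000 nM.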

Compound 4, half-maximal cytotoxic concentration: 66000 nM
Estimate against measurement, compound 4: 1.4-fold (0.13 log units) above; low and high end bracket the measured number.
By their numbers in this assay, from the lowest: compounds 4, 3 and 1 (each within the scatter of the next).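

In this assay the saturated chain carbon bound to an amide-type nitrogen and a carbonyl carbon now has its first measured step on this side chain, isobutyl in place of isopropyl (a 1.3-fold lower number from compound 3 to compound 4 (0.11 log units; within the scatter)). For the compounds shown here, this step lies within the scatter, so this one change does not separate compound 3 from compound 4 in this test, and the earlier compounds could not show that. No information given here bears on this side-chain change.

On these data alone, it remains open whether an amine on this side chain, or a longer chain such as n-hexyl, would move the number beyond the scatter. As far as these compounds go, it is also open whether isobutyl would behave the same way with the configuration drawn in compound 1.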